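Aryl-piperazine variation in a T-type calcium channel series

The compounds below may be only part of what the source reports. "The series", "measured", "known", "first", "only" and "open" are said of these compounds alone.

Compound 1 `CCCc1nc(-c2ccccc2)c(CNCCN2CCN(c3cccc(C(F)(F)F)c3)CC2)o1` is the reference point. In an assay on HEK293 cells for inhibition of Voltage-dependent T-type calcium channel subunit alpha-1G (Homo sapiens), read by fluorescence, tested at 10 uM (a higher number here means more inhibition at the concentration tested (going by the name of the read-out), a lower number less inhibition), compound 1 gives 56.3%, the lowest of the three numbers in hand, though both neighbours sit within the usual scatter of it: compound 2 `CCCc1nc(-c2ccccc2)c(CNCCCN2CCN(c3ccc(F)cc3)CC2)o1` gives 62.5% and compound 3 `CCCc1nc(-c2ccccc2)c(CNCCCN2CCN(c3ccccc3Cl)CC2)o1` gives 64.7%.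

Among the compounds with values here, the only measured step between compounds differing in one place is the move on the piperazine aryl group, a number 2.2 percentage points higher from compound 2 to compound 3 (within the scatter), which falls within the scatter.

Compound 4 `CCCc1nc(-c2ccccc2)c(CNCCN2CCN(c3ccccc3C(F)(F)F)CC2)o1` differs from compound 1 only in the aryl group on the same nitrogen: 2-(trifluoromethyl)phenyl in place of 3-(trifluoromethyl)phenyl on an amine nitrogen in a ring. Within the data shown here, the change is a shift of one substituent around the phenyl ring, and the one comparable step, from compound 2 to compound 3, was of no consequence. Nothing in hand points to a sizeable step in either direction in this assay, so the expected step is a number 1.7 percentage points higher from compound 1 to compound 4 (within the scatter), within the scatter. For compound 4 the estimate in this assay is therefore 58%, with a range from 42% to 74%.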

Compound 4, a percentage reported as inhibition, at one concentration (the size of the read-out at that concentration, not a potency): 54.6%
Compound 4: middle estimate off by 3.4 percentage points, on the high side; the measured number falls inside the stated range.
By their numbers in this assay, from the lowest: compounds 4, 1, 2 and 3 (each within the scatter of the next, the first and the last beyond it).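

Placing the trifluoromethyl group differently, with 2-(trifluoromethyl)phenyl in place of 3-(trifluoromethyl)phenyl on the amine nitrogen in the ring, gives in this assay a number 1.7 percentage points lower from compound 1 to compound 4 (within the scatter). Within the data shown here, this is the first step that keeps the substituent and changes only where it sits on the phenyl ring, and the read-out does not separate the two isomers. Like a number 2.2 percentage points higher from compound 2 to compound 3 (within the scatter), it leaves the number within the scatter, and no measured evidence at hand bears on this result.

Still open, as far as these compounds go, is whether a nitrile or a carboxylic acid on that phenyl ring, or a pyridine in its place, would move the number beyond the scatter. Since each number comes from a single concentration, potency differences among these compounds also remain unresolved.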